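Carbamate Ester Variation on a Thiazolidinedione Scaffold

A few compounds are considered here, and "the series" means these few. Any claim that something is new, unique, unknown or untested is made for them only; others in the source may bear on it.

Measured so far:
Compound 1 `COC(=O)N1CCC(Oc2cc(Oc3cccc(/C=C4\SC(=O)NC4=O)c3)ncn2)CC1` gives 1870 nM in a functional assay on CHO-K1 cells for agonist activity at Glucose-dependent insulinotropic receptor (Homo sapiens), read by cAMP accumulation and immunoassay, with a stated time of 1 h; on this read-out lower numbers stand for an effect already at smaller amounts and higher numbers for an effect only at larger amounts of compound.
Compound 2 `CC(C)COC(=O)N1CCC(Oc2cc(Oc3cccc(/C=C4\SC(=O)NC4=O)c3)ncn2)CC1` gives 720 nM in this assay.

Among the compounds with values here, of the two measured compounds, compound 2 stands at the lower number; its only neighbour is compound 1, and the step of a 2.6-fold lower number from compound 1 to compound 2 (0.41 log units; beyond the scatter) lies beyond the usual scatter of this measurement. That step is the single observation available for the position in question, the saturated chain carbon bound to an oxygen next to a carbonyl group on the carbamate end of the shared core.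

Compound 3 `O=C1NC(=O)/C(=C/c2cccc(Oc3cc(OC4CCN(C(=O)OCc5ccccc5)CC4)ncn3)c2)S1` differs from compound 2 at exactly this place: phenyl in place of isopropyl on a saturated chain carbon bound to an oxygen next to a carbonyl group. Put another way, the isobutoxycarbonyl group becomes a benzyloxycarbonyl group. Within the data shown here, the one earlier change at this position, from compound 1 to compound 2, replaced hydrogen by isopropyl and produced a modest improvement. Nothing measured tells how a phenyl ring behaves here, so the expectation is hedged: the number is expected to stay near that of compound 2, with a slight lean toward a smaller value, as the step of a 1.4-fold lower number from compound 2 to compound 3 (0.16 log units; within the scatter) expresses. Compound 3 is therefore estimated at 500 nM, within a range from 180 nM to 1500 nM.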

Compound 3, half-maximal effective concentration: 153 nM
Estimate against measurement, compound 3: 3.3-fold (0.51 log units) above; measured number outside the range, below it.
By their numbers in this assay, from the lowest: compound 3; then compound 2; then compound 1.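

In this assay, phenyl in place of isopropyl on a saturated chain carbon bound to an oxygen next to a carbonyl group brings a 4.7-fold lower number from compound 2 to compound 3 (0.67 log units; beyond the scatter) and so continues in the direction of the earlier change. Measured against the hydrogen of the first compound, phenyl at this place gives a 12-fold lower number from compound 1 to compound 3 (1.09 log units; beyond the scatter) and shows that this end of the molecule can shift the read-out substantially, with the numbers falling in the order hydrogen, isopropyl, phenyl and no compound shown going against that order. No measurement here offers an explanation for the gain from phenyl.

Isopropyl and phenyl differ both in heavy atoms and in the presence of an aromatic ring, so these compounds cannot tell whether the ring itself matters or simply the larger group, and cyclohexyl at the same place would help separate the two. Also open, as far as these compounds go, is how the number would respond to a substituted ring such as 4-fluorophenyl, a nitrogen-containing ring such as pyridyl, or a longer chain such as the phenethyl group.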